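Three measured analogues, one dimethylated guanidine still to test

The compounds below may be only part of what the source reports. "The series", "measured", "known", "first", "only" and "open" are said of these compounds alone.

Compound 1: `CC/N=C(/NC#N)NCCCn1nc(-c2ccccc2)ccc1=O` — 62.9%
Compound 2: `C=CCNC(=S)NCCCCn1nc(-c2ccccc2)ccc1=O` — 27.1%
Compound 3: `N#CNC(=N)NCCCCn1nc(-c2ccccc2)ccc1=O` — 61.2%

All three share one core and differ only in the group carried at the end of the saturated chain. In a functional assay on the whole organism with Rattus norvegicus as the target, at a dose of 100 mg/kg (a higher number here means more inhibition at the dose given (going by the name of the read-out), a lower number less inhibition), compound 3 gives 61.2%, the second highest of the three numbers; its nearest neighbour is compound 1, and the gap between them is within the scatter, so no order between these two can be claimed, while compound 2 lies well apart, as a number 34.1 percentage points higher from compound 2 to compound 3 (beyond the scatter) shows.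

Compound 4 is `CN(C)/C(=N/CCCn1nc(-c2ccccc2)ccc1=O)NC#N`. It differs from compound 3 in this way: a group of 8 heavy atoms (4 carbon, 4 nitrogen; no ring) in place of a group of 7 heavy atoms (3 carbon, 4 nitrogen; no ring), on a saturated chain carbon, three bonds along the chain from an aromatic nitrogen.

Within the data shown here, only one measured step bears directly on this kind of change: a number 1.7 percentage points lower from compound 1 to compound 3 (within the scatter), where the group at the same place was exchanged for a closely related one without any movement beyond the scatter. The two large steps, a number 35.8 percentage points lower from compound 1 to compound 2 (beyond the scatter) and a number 34.1 percentage points higher from compound 2 to compound 3 (beyond the scatter), both involve the sulfur-bearing group of compound 2 and so say little about compound 4. The change from compound 3 to compound 4 is therefore expected to produce no step beyond the scatter, and the estimated step is a number 2.2 percentage points lower from compound 3 to compound 4 (within the scatter).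

For compound 4 the expected inhibition is 59%, with a range from 42% to 74%.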

Compound 4, a percentage reported as inhibition, in the whole organism at one dose (the size of the read-out at that dose, not a potency): 72.2%
Compound 4: the middle estimate sits 13.2 percentage points below what was measured, within the range that was stated.
By their numbers in this assay, from the lowest: compound 2; then compounds 3, 1 and 4 (each within the scatter of the next, the first and the last beyond it).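

The change at this position, on a saturated chain carbon, three bonds along the chain from an aromatic nitrogen, now gives a step beyond the scatter without involving the sulfur-bearing group of compound 2: a number 11 percentage points higher from compound 3 to compound 4 (beyond the scatter) in this assay, though only a modest one. Compound 4 and compound 1 carry groups with the same heavy-atom count, 8 heavy atoms (4 carbon, 4 nitrogen), and a number 9.3 percentage points higher from compound 1 to compound 4 (within the scatter) leaves these two groups indistinguishable in this read-out, so the dimethylated guanidine keeps the level of compound 1 and no order between them can be claimed. The distance from the sulfur-bearing group also holds with this new group, at a number 45.1 percentage points higher from compound 2 to compound 4 (beyond the scatter), so compound 2 remains apart from compound 4 by a large step.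

The compounds shown leave open whether a longer chain ending in the same dimethylated guanidine, or a piperidine ring in place of its two methyl groups, would hold the number in this assay. Nothing available here gives a reason for any of these differences.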